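The source may hold more compounds than are shown below. What is called first, only, known or untested is meant among the compounds shown, and "the series" means these compounds.

Among the compounds with values here, compound 2 `O=C(Nc1cccc(Nc2ncc(F)c(Nc3ccc(F)cc3)n2)c1)c1ccncc1` stands lowest of the two numbers so far in a functional assay on A549 cells (Homo sapiens) for antiproliferative activity, read by sulforhodamine B assay, with a stated time of 3 days; on this read-out lower numbers stand for stronger inhibition of growth and higher numbers for weaker inhibition of growth; its nearest neighbour is compound 1 `O=C(c1cccc(Nc2ncc(F)c(Nc3ccc(F)cc3)n2)c1)N1CCCCC1`, with 13200 nM against 1650 nM for compound 2. Within the data shown here, the one step measured to date, an 8.0-fold lower number from compound 1 to compound 2 (0.90 log units; beyond the scatter), shows that the group on the carbonyl carbon of this side chain moves the read-out by a modest amount. Compound 3 `COCC(=O)Nc1cccc(Nc2ncc(F)c(Nc3ccc(F)cc3)n2)c1` keeps the amide-type nitrogen of compound 2 and changes only the group on the carbonyl carbon: methoxymethyl in place of pyridin-4-yl on a carbonyl carbon. Among the measured compounds shown here, no measured step covers this exchange, so the direction rests only on the observation that the carbonyl substituent is sensitive at all. The expected step for compound 3 is a mild rise in the number, a 2.1-fold higher number from compound 2 to compound 3 (0.33 log units; beyond the scatter), with a wide range. Compound 3 is therefore estimated at 3500 nM in this assay, between 1000 nM and 12000 nM.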

Compound 3, concentration for 50% growth inhibition: 2050 nM
The estimate for compound 3 lay 1.7-fold (0.23 log units) above the measured number; measured number inside the range.
By their numbers in this assay, from the lowest: compounds 2 and 3 (each within the scatter of the next); then compound 1.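

In this assay the step of a 1.2-fold higher number from compound 2 to compound 3 (0.09 log units; within the scatter) shows that methoxymethyl in place of pyridin-4-yl on a carbonyl carbon gives no readable change, so at this position the six-membered aromatic ring can give way to an open chain of 3 heavy atoms without a shift in the number. The step of a 6.4-fold lower number from compound 1 to compound 3 (0.81 log units; beyond the scatter) shows that the lower number relative to compound 1 does not depend on pyridin-4-yl, since ((methoxymethyl)carbonyl)amino in place of (piperidin-1-yl)carbonyl on an aromatic carbon also gives a drop beyond the scatter. Nothing available bears on the reason for either step.

From the compounds shown here alone, whether an amine, a carboxylic acid or a longer chain on this carbonyl carbon would hold the same level remains open. The steps from compound 1 change the amide direction and the attached group together, and the compounds shown cannot separate the two.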